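Acetylation of the ring amino group in the series

A few compounds are considered here, and "the series" means these few. Any claim that something is new, unique, unknown or untested is made for them only; others in the source may bear on it.

Measured compounds:
compound 1 `Cc1nc2c(OCc3ccccc3)cccn2c1N`: 97%
compound 2 `Cc1nc2c(OCc3cccs3)cccn2c1N`: 77%

In a functional assay on the whole organism with Canis familiaris (Canis lupus familiaris) as the target, at a dose of 2 mg/kg by the intravenous route (on this read-out higher numbers stand for a stronger effect at the one dose given and lower numbers for a weaker effect), compound 1 gives 97%, the highest of the two numbers. Among the measured compounds shown here, compound 2 gives 77%, with a number 20 percentage points lower from compound 1 to compound 2 (beyond the scatter), the only step measured so far, and it concerns the group on the saturated chain carbon bound to the oxygen, not the nitrogen.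

Compound 3 `CC(=O)Nc1c(C)nc2c(OCc3ccccc3)cccn12` differs from compound 1 by acetyl in place of hydrogen on a nitrogen on an aromatic ring. For the measured compounds named here, no measured step touches this nitrogen, so nothing measured bears directly on the change; the one known step only shows that the series tolerates a change elsewhere with a modest loss. Going by the values given here, for compound 3 a step of a number 27 percentage points lower from compound 1 to compound 3 (beyond the scatter) is expected, downward, since the acetamido has no precedent here and compound 1 already sits near the top of the scale. Compound 3 is estimated at 70%, in the range 35% to 97%.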

Compound 3, a percentage reported as inhibition, in the whole organism at one dose (the size of the read-out at that dose, not a potency): 24%
Compound 3: the middle estimate sits 46 percentage points above what was measured; the measured number lies below the stated range.
By their numbers in this assay, from the lowest: compound 3; then compound 2; then compound 1.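

In this assay, the change from amino to acetamido gives a number 73 percentage points lower from compound 1 to compound 3 (beyond the scatter), so this nitrogen, which the earlier pair left untouched, is a position where a single change can remove most of the read-out. This is one step at one dose, so it shows a large loss of effect at that dose and gives no measure of potency. The data offered no measurement that would account for the loss.

The compounds shown leave open whether the loss belongs to acetyl itself or extends to other groups on this nitrogen, such as a methyl, a longer acyl chain like propionyl, or a methanesulfonyl. They also leave open whether acetyl on the nitrogen costs as much with the thiophen-2-yl group in place of phenyl.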